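The source may report more compounds than this note shows. Statements on the series, on what has been measured and on what is new or still open speak of the compounds shown alone.

Compound 1 `Cc1nc(NCc2ccccc2)c2cnn(-c3ccccc3)c2n1` gives > 100000 nM in a functional assay on G-361 cells (Homo sapiens) for cytotoxicity, read by sulforhodamine B assay (on this read-out higher numbers stand for weaker inhibition of growth and lower numbers for stronger inhibition of growth), which is a limit of the assay and not a number.
Compound 2 `CCNc1nc(C)nc2c1cnn2-c1ccccc1` gives > 100000 nM in this assay, again a limit of the assay.

Compound 2 therefore stands at the edge of what this assay can report: the limit of > 100000 nM in this assay, at which 2 of the 2 values shown sit. Among the measured compounds shown here, the one measured step that could be read here runs from compound 1 to compound 2, and it is a step that the two limits leave unreadable from compound 1 to compound 2, so it gives no measure of how much this kind of change matters.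

Compound 3 `CCNCc1nc(NCC)c2cnn(-c3ccccc3)c2n1` differs from compound 2 by ethylamino in place of hydrogen on a saturated chain carbon bound to an aromatic carbon. For the measured compounds named here, no measured step touches this position, and the only measured step is unreadable, so the two limits give no direction and no size to build on. The expectation for compound 3 is simply that it stays where compound 2 stands, with the step from compound 2 to compound 3 estimated as a number no higher from compound 2 to compound 3 (the limit leaves the size open). Compound 3 is therefore expected to give about 100000 nM in this assay, within a range from 30000 nM to 300000 nM, most likely reported once more as a limit.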

Compound 3, concentration for total growth inhibition: > 100000 nM
Compound 3 was reported as a limit (the forecaster's own chance of this, stated with the estimate: 75%); the middle value lies on the limit itself.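

Compound 2 and compound 3 give no new step that can be read, since each is reported only as a limit of the assay and not as a number: the limit of > 100000 nM in this assay, at which 3 of the 3 values shown sit.

The compounds shown leave open how much the added ethylamino group, or any other change to the shared core, affects inhibition of growth.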